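The source may hold more compounds than are shown below. What is called first, only, known or untested is meant among the compounds shown, and "the series" means these compounds.

Working notes on the series. In a functional assay on cells for antagonist activity at C-C chemokine receptor type 4 (Homo sapiens), read by fluorescence and calcium flux, with stated times of 2.5 s and 45 s (a higher number here means a weaker inhibitor, a lower number a stronger inhibitor), compound 1 `CC1CN(c2cnc3cnn(C(C)c4ccc(Cl)cc4Cl)c3n2)CCC1N1CCCCC1` gives 238 nM. Compound 2 `CC1CN(c2cnc3c(C(N)=O)nn(C(C)c4ccc(Cl)cc4Cl)c3n2)CCC1N1CCCCC1` gives 228 nM in this assay; the step of a 1.0-fold lower number from compound 1 to compound 2 (0.02 log units; within the scatter) is carbamoyl in place of hydrogen on an aromatic carbon of the shared core. Compound 3 `C[C@@H]1CC(c2cnc3c(C#N)nn([C@H](C)c4ccc(Cl)cc4Cl)c3n2)=CC[C@@H]1N1CCC[C@H]1CO` gives 40 nM in this assay, the lowest of the three numbers; compound 2 is the nearest of the other two and compound 1 the furthest, and both stand beyond the scatter from it.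

Compound 4 `C[C@@H]1CC(c2cnc3c(C#N)nn([C@H](C)c4ccc(Cl)cc4Cl)c3n2)=CC[C@@H]1N1CCC[C@H]1C(C)(C)O` is the next step from compound 3: 1-hydroxy-1-methylethyl in place of hydroxymethyl on a saturated ring carbon. For the measured compounds named here, no measured step bears directly on this change. Going by the values given here, the one step measured so far, from compound 1 to compound 2, concerns a different part of the molecule, an aromatic carbon of the core, and stayed within the scatter. Among the compounds with values here, there is thus no precedent for enlarging the hydroxymethyl on the five-membered non-aromatic ring with one nitrogen to 1-hydroxy-1-methylethyl, and the expectation can only be the neutral one: a step in this assay of no size beyond the scatter, in either direction, with a range widened to reflect the missing precedent. Compound 4 is therefore estimated at 40 nM, between 14 nM and 115 nM, which means an expected step of no change at the digits printed from compound 3 to compound 4 (within the scatter).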

Compound 4, half-maximal inhibitory concentration: 384 nM
Compound 4: middle estimate off by 9.6-fold (0.98 log units), on the low side, and the stated range ends below it.
By their numbers in this assay, from the lowest: compound 3; then compounds 2, 1 and 4 (each within the scatter of the next).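

For the compounds shown here, on the saturated ring carbon next to the ring nitrogen, the group is not interchangeable: 1-hydroxy-1-methylethyl in place of hydroxymethyl gives a 9.6-fold higher number from compound 3 to compound 4 (0.98 log units; beyond the scatter) in this assay and marks this position as sensitive to the change, whereas the only earlier step, made on an aromatic carbon of the shared core, stayed within the scatter. The hydrogen-bond donor and acceptor counts and the absence of net charge are the same on both sides of this step, and the group grows from 2 heavy atoms to 4 heavy atoms, the added atoms being carbon. Nothing at hand gives a cause for the size of this step.

As far as these compounds go, with a single pair at this position, it remains open whether the rise in the number appears gradually with size or only with the full 1-hydroxy-1-methylethyl group, a question that 1-hydroxyethyl would address directly. Also open, from the compounds shown here alone, is how other replacements for hydroxymethyl on this ring carbon, such as methoxymethyl, aminomethyl or a carboxylic acid, would compare with compound 3 in this assay when the rest of the molecule is unchanged.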